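Replacing tert-butoxy with hydrogen on the aromatic ring

This account rests on a few compounds, and the source may have more. Where it says the series, first, only, none or still open, it means among the compounds named here.

In a functional assay on A-431 cells (Homo sapiens) for inhibition, read by MTT assay, with a stated time of 72 h (a higher number here means a weaker inhibitor, a lower number a stronger inhibitor), compound 1 (`Cc1ccc(-c2nnc(SCCCN3CCN(c4nc5ccccc5o4)CC3)o2)cc1`) gives 100000 nM and compound 2 (`CC(C)(C)Oc1ccc(-c2nnc(SCCCN3CCN(c4nc5ccccc5o4)CC3)o2)cc1`) gives 65800 nM. Among the compounds with values here, compound 2 therefore stands within the scatter of compound 1, the only other measured compound, and the two cannot be told apart. Compound 3 (`c1ccc(-c2nnc(SCCCN3CCN(c4nc5ccccc5o4)CC3)o2)cc1`) has hydrogen in place of tert-butoxy on an aromatic carbon, para to a large group: hydrogen in place of tert-butoxy on an aromatic carbon. Within the data shown here, only one measured step bears on this change, a 1.5-fold lower number from compound 1 to compound 2 (0.18 log units; within the scatter), and it exchanged one group for another at an aromatic carbon. Among the measured compounds shown here, no measured compound yet shows the effect of leaving that carbon with hydrogen, so the evidence is thin. A step beyond the scatter in this assay is not expected, and no firm direction can be assigned. The expected change is a 1.2-fold higher number from compound 2 to compound 3 (0.08 log units; within the scatter). For compound 3, the estimated value is 80000 nM, with an expected range of 40000 nM to 140000 nM.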

Compound 3, half-maximal inhibitory concentration: 57600 nM
Compound 3: middle estimate off by 1.4-fold (0.14 log units), on the high side; the measured number falls inside the stated range.
By their numbers in this assay, from the lowest: compounds 3, 2 and 1 (each within the scatter of the next).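

With hydrogen on this aromatic carbon, para to a large group, the series now has a reference without any substituent there. In this assay, hydrogen in place of tert-butoxy gives (a 1.1-fold lower number from compound 2 to compound 3 (0.06 log units; within the scatter)) and hydrogen in place of methyl gives (a 1.7-fold lower number from compound 1 to compound 3 (0.24 log units; within the scatter)). Neither methyl nor tert-butoxy, with its 5 heavy atoms, therefore separates from hydrogen at this position, and the earlier pair alone could not show this. No available evidence accounts for this result. The compounds shown leave open whether an amine, a carboxylic acid or a fluorine atom on this carbon would move the number beyond the scatter. They also leave open what a change elsewhere would do, as all three compounds share the rest of the structure.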